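Adding a methyl to an ether chain in a resistant-cell assay

The source may report more compounds than this note shows. Statements on the series, on what has been measured and on what is new or still open speak of the compounds shown alone.

Measured so far:
compound 1, `COCc1cc(CN2CCCC2)c(O)c2ncccc12`: 3550 nM
compound 2, `CCOCc1cc(CN2CCCC2)c(O)c2ncccc12`: 5250 nM
compound 3, `CCOCc1cc(CN2CCC(C)CC2)c(O)c2ncccc12`: 3020 nM

These three compounds were tested in a functional assay on MES-SA/Dx5 cells (Homo sapiens) for inhibition, with a stated time of 72 h, in the presence of a further agent that is not named here; a higher number here means a weaker inhibitor, a lower number a stronger inhibitor. Compound 2 differs from compound 1 by methyl in place of hydrogen on a saturated chain carbon bound to an oxygen on a saturated carbon, and the step of a 1.5-fold higher number from compound 1 to compound 2 (0.17 log units; within the scatter). Compound 3 differs from compound 2 by a change of the amine, and the step of a 1.7-fold lower number from compound 2 to compound 3 (0.24 log units; within the scatter). The difference between the cores of compound 1 and compound 3 is not broken down here.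

Compound 4, `CC1CCN(Cc2cc(COC(C)C)c3cccnc3c2O)CC1`, has not been measured. It differs from compound 3 by methyl in place of hydrogen on a saturated chain carbon bound to an oxygen on a saturated carbon and a saturated chain carbon. This is the same kind of change as that from compound 1 to compound 2, but the place now also carries a saturated chain carbon. Because compound 1 to compound 2 gave a 1.5-fold higher number from compound 1 to compound 2 (0.17 log units; within the scatter), a similar small step is expected here, namely a 1.3-fold higher number from compound 3 to compound 4 (0.12 log units; within the scatter). Compound 4 is therefore estimated at 4000 nM, with a likely range from 1800 nM to 9000 nM.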

Compound 4, half-maximal inhibitory concentration: 2140 nM
Beside the measured number, compound 4's estimate is 1.9-fold (0.27 log units) above it; measured number inside the range.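

In this assay, turning ethoxy into isopropoxy gives a 1.4-fold lower number from compound 3 to compound 4 (0.15 log units; within the scatter). The earlier methyl addition and this one have opposite signs, but the gap between them is no larger than repeated measurements would produce: the same change on two cores in this assay, a 1.5-fold higher number (0.17 log units; within the scatter) from compound 1 to compound 2 and a 1.4-fold lower number (0.15 log units; within the scatter) from compound 3 to compound 4, 2.1-fold (0.32 log units) apart, within the scatter of two such steps. This shows that the methyl addition had only a small effect on both cores, but it does not establish a direction for the effect, and two small steps are too few to show how the change will behave on other cores.

The compounds shown leave open what a longer chain, such as butyl, would do on the ether oxygen. They also leave open whether a carboxylic acid in place of the ether chain would move the number in this assay beyond the scatter.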